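Adding a chlorine to compound 2: what to expect

This account rests on a few compounds, and the source may have more. Where it says the series, first, only, none or still open, it means among the compounds named here.

Compound 1 `Cc1nc(Nc2ccc(Cl)cc2)sc1C(=O)/C=C/c1ccccc1` gives in a functional assay on Bel-7402 cells (Homo sapiens) for cytotoxicity, read by MTT assay (on this read-out lower numbers stand for stronger inhibition and higher numbers for weaker inhibition), only a limit of the assay, > 25000 nM. Compound 2 `Cc1nc(Nc2ccc(Cl)c(Cl)c2)sc1C(=O)/C=C/c1ccccc1` gives in this assay 21500 nM. Compound 3 `Cc1nc(Nc2ccccc2)sc1C(=O)/C=C/c1ccccc1` likewise reaches only the assay limit, > 25000 nM.

Going by the values given here, compound 2 thus holds the sole number in this assay; the other two values are limits (the limit of > 25000 nM in this assay, at which 2 of the 3 values shown sit). Compound 4 `Cc1nc(Nc2ccc(Cl)c(Cl)c2)sc1C(=O)/C=C/c1ccc(Cl)cc1` differs from compound 2 by chloro in place of hydrogen on an aromatic carbon. The measured steps all touch the other ring: an at least 1.1-fold lower number from compound 1 to compound 2 (0.06 log units; that floor lies within the scatter), an at least 1.1-fold higher number from compound 2 to compound 3 (0.06 log units; that floor lies within the scatter) and a step that the two limits leave unreadable from compound 1 to compound 3. None reads beyond the scatter, and none touches the phenyl that here becomes 4-chlorophenyl. Compound 4 is therefore expected to give about 15000 nM, between 6000 nM and 40000 nM. That expectation means a step of a 1.4-fold lower number from compound 2 to compound 4 (0.16 log units; within the scatter), within the scatter.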

Compound 4, half-maximal inhibitory concentration: > 25000 nM
Compound 4 gave a limit, no number (the forecaster's own chance of this, stated with the estimate: 30%); middle value at least 1.6-fold (0.22 log units) away from the limit.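

Compound 4 gives only a limit of the assay, not a number. This is the first step shown on the phenyl that becomes 4-chlorophenyl, and in this assay it reads as an at least 1.1-fold higher number from compound 2 to compound 4 (0.06 log units; that floor lies within the scatter), so chloro at this position brought no lower number, although the true size of the step remains unknown. Compound 2 still holds the sole number in the set: the limit of > 25000 nM in this assay, at which 3 of the 4 values shown sit.

From the compounds shown here alone, whether an amine or a methoxy group at this position would give a number under the limit stays open. So does how far compound 4 lies past its limit.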